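Iodo for Fluoro on the Amino-Phenyl Ring

The source may hold more compounds than are shown below. What is called first, only, known or untested is meant among the compounds shown, and "the series" means these compounds.

The three measured compounds share one core and differ in the aryl group on a nitrogen on an aromatic ring. Compound 1 `CCc1ccc(Nc2cc(NC(=O)Nc3cc(OC)cc(OC)c3)ncn2)cc1` gives 50.1% in a functional assay on NCI-H226 cells (Homo sapiens) for inhibition, read by MTT assay, with a stated time of 48 h, tested at 10 uM; a higher number here means more inhibition at the concentration tested (going by the name of the read-out), a lower number less inhibition. Compound 2 `COc1cc(NC(=O)Nc2cc(Nc3cccc(C(C)(C)C)c3)ncn2)cc(OC)c1` gives 40% there, and compound 3 `COc1cc(NC(=O)Nc2cc(Nc3cc(F)ccc3OC)ncn2)cc(OC)c1` gives 37.7%. Compound 3 stands lowest of the three numbers: the step of a number 12.4 percentage points lower from compound 1 to compound 3 (beyond the scatter) lies beyond the scatter, while the step of a number 2.3 percentage points lower from compound 2 to compound 3 (within the scatter) lies within it, so compound 3 and compound 2 cannot be ordered against each other.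

Compound 4 `COc1cc(NC(=O)Nc2cc(Nc3cc(I)ccc3OC)ncn2)cc(OC)c1` is not yet measured. It differs from compound 3 in one place: iodo in place of fluoro on an aromatic carbon. The change sits on an aromatic carbon of a six-membered aromatic ring of carbon only, para to a methoxy group. Among the measured compounds shown here, no measured step swaps one halogen for another; the steps of a number 10.1 percentage points lower from compound 1 to compound 2 (beyond the scatter) and a number 12.4 percentage points lower from compound 1 to compound 3 (beyond the scatter) replace the whole aryl group and so bear only loosely on this change. For the measured compounds named here, with no closer precedent, compound 4 is expected to stay within the scatter of compound 3, and the estimated step is a number 2.3 percentage points higher from compound 3 to compound 4 (within the scatter). Compound 4 is therefore estimated at 40%, with a range from 26% to 56%.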

Compound 4, a percentage reported as inhibition, at one concentration (the size of the read-out at that concentration, not a potency): 56.7%
Beside the measured number, compound 4's estimate is 16.7 percentage points below it; measured number above the stated range.
By their numbers in this assay, from the lowest: compounds 3 and 2 (each within the scatter of the next); then compounds 1 and 4 (each within the scatter of the next).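

In this assay the exchange of a single atom on this aromatic carbon, para to a methoxy group, gives a number 19 percentage points higher from compound 3 to compound 4 (beyond the scatter) with no change in the count of rings, hydrogen-bond donors or hydrogen-bond acceptors. The 5-iodo-2-methoxyphenyl group also separates from the 3-(tert-butyl)phenyl group, with a number 16.7 percentage points higher from compound 2 to compound 4 (beyond the scatter) in that comparison, whereas the exchange for the 4-ethylphenyl group gives a number 6.6 percentage points higher from compound 1 to compound 4 (within the scatter) and leaves those two compounds unordered. Nothing available here explains why iodo gives the higher number at this position.

Going by these compounds, what chloro or bromo would give on this aromatic carbon remains open, as does whether a nitrile there would behave like iodo or like fluoro. On these data alone, it is also open whether the gain from iodo would carry over to a ring without the methoxy group.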